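Swapping a Branched Chain for a Methylbenzyl Group

This account rests on a few compounds, and the source may have more. Where it says the series, first, only, none or still open, it means among the compounds named here.

Compound 1 `CCCCCCCn1ccc2cc(/C(C)=C/C(=O)Nc3ccccc3OCCCC(=O)O)ccc21` gives 120 nM in an assay on Prostate gland for inhibition of steroid 5-alpha-reductase (Rattus norvegicus); on this read-out higher numbers stand for weaker inhibition and lower numbers for stronger inhibition.
Compound 2 `CCCC(C)n1ccc2cc(/C(C)=C/C(=O)Nc3ccccc3OCCCC(=O)O)ccc21` gives 7.8 nM in this assay.
Compound 3 `CCCCC(CCCC)n1ccc2cc(/C(C)=C/C(=O)Nc3ccccc3OCCCC(=O)O)ccc21` gives 21 nM in this assay.

Compound 3 stands second highest of the three numbers: the step that ends at it from its nearest neighbour is a 2.7-fold higher number from compound 2 to compound 3 (0.43 log units; beyond the scatter), and the step that ends at it from its furthest is a 5.7-fold lower number from compound 1 to compound 3 (0.76 log units; beyond the scatter). All three share one core and differ only in the group on the aromatic nitrogen.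

Compound 4 `C/C(=C\C(=O)Nc1ccccc1OCCCC(=O)O)c1ccc2c(ccn2Cc2cccc(C)c2)c1` carries a different kind of group there: 3-methylbenzyl in place of 1-butylpentyl on an aromatic nitrogen. The measured steps that bear on this place are a 5.7-fold lower number from compound 1 to compound 3 (0.76 log units; beyond the scatter) and a 2.7-fold higher number from compound 2 to compound 3 (0.43 log units; beyond the scatter); both compare chains of carbon, one larger than the other, and neither brings in a ring. The new group is close in heavy-atom count to the one it replaces, so the nearest guide is compound 3 itself, with the step of a 2.7-fold higher number from compound 2 to compound 3 (0.43 log units; beyond the scatter) showing that a smaller group can reach a lower number. Compound 4 is therefore expected to land near compound 3, at about 20 nM, within a range from 5 nM to 80 nM. The expected step, a 1.1-fold lower number from compound 3 to compound 4 (0.02 log units; within the scatter), is not expected to go beyond the scatter in either direction.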

Compound 4, half-maximal inhibitory concentration: 250 nM
Compound 4: the middle estimate sits 13-fold (1.10 log units) below what was measured; measured number outside the range, above it.
By their numbers in this assay, from the lowest: compound 2; then compound 3; then compound 1; then compound 4.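

The heavy-atom count proves a poor guide at this position on the aromatic nitrogen: 3-methylbenzyl has 8 heavy atoms against 9 in 1-butylpentyl, all carbon in both groups, yet the one six-membered aromatic ring it brings comes with a large loss of inhibition. In this assay the replacement of 1-butylpentyl gives a 12-fold higher number from compound 3 to compound 4 (1.08 log units; beyond the scatter) and the replacement of the smaller 1-methylbutyl gives a 32-fold higher number from compound 2 to compound 4 (1.51 log units; beyond the scatter) and so both branched chains stand far ahead of the ring-bearing group. Even the unbranched heptyl chain of compound 1, the weakest of the three earlier compounds, keeps a modest lead, as the step of a 2.1-fold higher number from compound 1 to compound 4 (0.32 log units; beyond the scatter) shows, which leaves compound 4 with the highest number of the four.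

No measurement shown gives a reason for this rise. The compounds shown also leave open whether the ring or the methyl on it goes with the higher number, a question that an unsubstituted benzyl group or a saturated cyclohexylmethyl group on the same nitrogen would help to settle.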